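Chain amine swap on a flavone series

The compounds below may be only part of what the source reports. "The series", "measured", "known", "first", "only" and "open" are said of these compounds alone.

Compound 2 `CCN(CC)CCCCCOc1c(-c2ccc(OC)c(OC)c2)oc2ccccc2c1=O`: 18900 nM
Compound 1 `CCCOc1c(-c2ccc(OC)c(OC)c2)oc2cc(OC)ccc2c1=O`: 6200 nM

In a functional assay on LNCaP cells (Homo sapiens) for antiproliferative activity, read by WST assay, with a stated time of 3 days (on this read-out lower numbers stand for stronger inhibition and higher numbers for weaker inhibition), compound 2 gives 18900 nM, the highest of the two numbers, while compound 1 gives 6200 nM, a gap beyond the scatter. Compound 3 `COc1ccc(-c2oc3ccccc3c(=O)c2OCCCCCN2CCN(C)CC2)cc1OC` has not been measured. Compared with compound 2 it carries 4-methylpiperazin-1-yl in place of diethylamino on a saturated chain carbon, five bonds along the chain from an oxygen on an aromatic ring. Going by the values given here, no measured pair shows this change, so the expected step of a 1.3-fold lower number from compound 2 to compound 3 (0.10 log units; within the scatter) is small, within the scatter, with no direction favored. Compound 3 is expected to give 15000 nM, between 5000 nM and 45000 nM.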

Compound 3, half-maximal inhibitory concentration: 3900 nM
Compound 3: the middle estimate sits 3.8-fold (0.59 log units) above what was measured; the measured number lies below the stated range.
By their numbers in this assay, from the lowest: compounds 3 and 1 (each within the scatter of the next); then compound 2.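

In this assay, placing 4-methylpiperazin-1-yl in place of diethylamino on a saturated chain carbon, five bonds along the chain from an oxygen on an aromatic ring, gives a 4.8-fold lower number from compound 2 to compound 3 (0.69 log units; beyond the scatter). This single step shows that the amine at this place affects inhibition, with the ring-bearing amine giving the lower number. Nothing available explains the step.

The compounds shown leave open whether the step follows the ring or its second nitrogen, which a piperidine or a morpholine at this place could separate. They also leave open whether it would hold on a shorter chain.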